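From cyano to hydrogen: what compound 4 may show

The source may report more compounds than this note shows. Statements on the series, on what has been measured and on what is new or still open speak of the compounds shown alone.

Measured in a physicochemical assay for lipophilicity; a lower number here means a more polar compound, a higher number a more lipophilic compound:
- compound 1 `C[C@H]1CC[C@@H]2[C@@H](OC(=O)[C@]23CC(c2ccc(N(C)C)cc2)=NO3)[C@]2(C)C(=O)C=C[C@@]12O`: 1.51
- compound 2 `C[C@H]1CC[C@@H]2[C@@H](OC(=O)[C@]23CC(c2ccc(F)cc2)N(c2ccccc2)O3)[C@]2(C)C(=O)C=C[C@@]12O`: 3.35
- compound 3 `C[C@H]1CC[C@@H]2[C@@H](OC(=O)[C@]23CC(c2ccc(C#N)cc2)N(c2ccccc2)O3)[C@]2(C)C(=O)C=C[C@@]12O`: 2.94

Among these three, compound 3 holds the middle place. It lies below compound 2 and well above compound 1.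

The next compound to be measured is compound 4 `C[C@H]1CC[C@@H]2[C@@H](OC(=O)[C@]23CC(c2ccccc2)N(c2ccccc2)O3)[C@]2(C)C(=O)C=C[C@@]12O`. It comes from compound 3 by one change: hydrogen in place of cyano on an aromatic carbon. In words, this is hydrogen in place of cyano on an aromatic carbon, turning 4-cyanophenyl into phenyl.

Among the measured compounds shown here, only one measured step touches this same place on the ring: a number 0.41 log units lower from compound 2 to compound 3 (beyond the scatter), where cyano took the place of fluoro. Compound 1 differs from compound 3 in more than one place, so it offers no guide here. Removing the cyano group should therefore move this assay back upward, by roughly the size of that one step or a little less. For the measured compounds named here, this remains a cautious expectation, since no step from fluoro to hydrogen has been measured.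

The expected change is a number 0.31 log units higher from compound 3 to compound 4 (beyond the scatter). For compound 4 the estimated value is 3.25, with an expected range from 2.95 to 3.55.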

Compound 4, partition coefficient: 3.19
Compound 4: middle estimate off by 0.06 log units, on the high side; the measured number falls inside the stated range.
By their numbers in this assay, from the lowest: compound 1; then compounds 3, 4 and 2 (each within the scatter of the next, the first and the last beyond it).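

Among the compounds shown here, this position now has three substituents to compare, and the picture is less simple than the single earlier step suggested. In this assay, removing cyano gives a number 0.25 log units higher from compound 3 to compound 4 (within the scatter), and removing fluoro gives a number 0.16 log units lower from compound 2 to compound 4 (within the scatter), so the plain phenyl compound cannot be told apart from either substituted compound, even though those two are separated by a number 0.41 log units lower from compound 2 to compound 3 (beyond the scatter). Only the swap between fluoro and cyano is large enough to read at this place on the ring, and no measurement shown here bears on why the numbers fall this way.

On these data alone, with only hydrogen, fluoro and cyano to compare on this aromatic carbon, it remains open whether a carboxylic acid or a longer alkyl chain there would shift this assay well beyond the scatter, and in which direction. As far as these compounds go, compound 1 carries a dimethylamino group on its ring, but it differs from the others in more than one place, so the effect of that group alone also remains open.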